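The source may hold more compounds than are shown below. What is called first, only, known or untested is meant among the compounds shown, and "the series" means these compounds.

Measured so far in an assay on HeLa cells for displacement of a labelled ligand from adenosine receptor A3 (Homo sapiens), read by scintillation counting, with a stated time of 180 min, tested at 10 uM; a lower number here means less inhibition, a higher number more inhibition at the concentration tested (going by the name of the read-out):
compound 1 `O=C(O)CNC(=O)c1cc2ccccc2oc1=O`: 0%
compound 2 `COc1cccc2cc(C(=O)NC3CCCCC3)c(=N)oc12`: 16%

Compound 2 holds the higher of the two numbers in this assay; compound 1 stands lower by a margin beyond the usual scatter, so compound 2 is the starting point for the next change. Compound 3 `COc1cccc2cc(C(=O)NCCCCCO)c(=N)oc12` differs from compound 2 in one place: 5-hydroxypentyl in place of cyclohexyl on an amide-type nitrogen. Among the compounds with values here, no step between measured compounds covers this kind of exchange, and compounds 1 and 2 differ in several places at once, so their two values alone say nothing about what this single change does. With compound 2 already low in this assay, the expected step, a number 6 percentage points lower from compound 2 to compound 3 (within the scatter), is small and downward, or none beyond the scatter. Compound 3 is estimated at 10%, with a range from 0% to 25%.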

Compound 3, a percentage reported as inhibition, at one concentration (the size of the read-out at that concentration, not a potency): 13%
The estimate for compound 3 lay 3 percentage points below the measured number; low and high end bracket the measured number.
By their numbers in this assay, from the lowest: compound 1; then compounds 3 and 2 (each within the scatter of the next).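

On the amide-type nitrogen, 5-hydroxypentyl in place of cyclohexyl gives, in this assay, a number 3 percentage points lower from compound 2 to compound 3 (within the scatter), so with an open chain with one hydrogen-bond donor and one hydrogen-bond acceptor in place of a carbon-only ring of equal heavy-atom count the number stays level, with no shift beyond the scatter. The ring itself is therefore not needed to keep the read-out at this level, though compound 2 at 16% and compound 3 at 13% are single-concentration numbers, not potencies. No measurement bears on why the exchange leaves the number within the scatter.

On these data alone, since ring and hydroxyl change together in this step, their separate contributions stay open. As far as these compounds go, whether a plain pentyl chain, a longer chain, an amine or a carboxylic acid on this nitrogen would move the number beyond the scatter also remains open.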